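Will Compound 3 Lower the Unbound Share Further?

This account rests on a few compounds, and the source may have more. Where it says the series, first, only, none or still open, it means among the compounds named here.

Measured in an ADME assay for protein binding, using equilibrium dialysis, at pH 7.4, tested at 2 uM; a higher number here means a larger unbound share of the compound, a lower number a smaller unbound share:
- Compound 1 `CC(C)N(C(=O)C1CCC(F)(F)CC1)c1cc(C#CC(C)(C)C)sc1C(=O)O`: 0.4
- Compound 2 `CC(C)N(c1cc(C#CC(C)(C)C)sc1C(=O)O)C(=O)[C@H]1CC[C@H](CF)CC1`: 0.18

Compound 2, at 0.18, holds the lower of the two numbers in this assay. Going by the values given here, the only measured step is a 2.2-fold lower number from compound 1 to compound 2 (0.35 log units; beyond the scatter). It is modest but lies beyond the scatter, and it replaces 4,4-difluorocyclohexyl with 4-(fluoromethyl)cyclohexyl on a carbonyl carbon.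

Compound 3 `CC(C)N(C(=O)[C@H]1CC[C@@H]2C[C@@H]2CC1)c1cc(C#CC(C)(C)C)sc1C(=O)O` keeps the shared core and changes that same place: a group of 8 heavy atoms (8 carbon; one three-membered non-aromatic ring of carbon only, one seven-membered non-aromatic ring of carbon only) in place of a group of 8 heavy atoms (7 carbon, 1 fluorine; one six-membered non-aromatic ring of carbon only), on a carbonyl carbon. The fluorine of compound 2 leaves with the old group, and the group that enters contains carbon only.

Among the compounds with values here, one step is thin evidence, and no measured compound carries the new ring pair. Still, the drop in a 2.2-fold lower number from compound 1 to compound 2 (0.35 log units; beyond the scatter) also came with a loss of fluorine, so a further small drop is expected rather than a rise. The expected change is a 1.8-fold lower number from compound 2 to compound 3 (0.26 log units; within the scatter), which may not clear the scatter. For compound 3, the estimated unbound fraction is 0.1, with an expected range from 0.04 to 0.25.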

Compound 3, unbound fraction: 0.08
Compound 3: the middle estimate sits 1.3-fold (0.10 log units) above what was measured; low and high end bracket the measured number.
By their numbers in this assay, from the lowest: compound 3; then compound 2; then compound 1.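

Removing the last fluorine from this group still moves the number: in this assay the new group gives (a 2.3-fold lower number from compound 2 to compound 3 (0.35 log units; beyond the scatter)), so the place on the carbonyl carbon has now produced a second step beyond the scatter, and this one comes from a group of the same heavy-atom size. Over the whole series, the change from the 4,4-difluorocyclohexyl group to the carbon-only ring pair gives (a 5.0-fold lower number from compound 1 to compound 3 (0.70 log units; beyond the scatter)), a larger change than either single step, with the amide-type nitrogen and the shared core left as they were. Within these three compounds, the unbound share falls as fluorine is lost from this group, and none of them goes against that order, although three compounds are too few to call it a general rule.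

Fluorine and ring shape change together in the last step, so these numbers cannot separate the two, and nothing measured here explains the falling numbers. A plain cycloheptyl group, carrying the seven-membered ring without the three-membered one, would help to separate them, and a cyclohexyl group bearing an amine would show how this place responds to a group that is not made of carbon and fluorine alone.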